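Swapping 4-bromophenyl for 2-hydroxyethyl: expected potency

The source may hold more compounds than are shown below. What is called first, only, known or untested is meant among the compounds shown, and "the series" means these compounds.

Three compounds have been measured in a functional assay on A549 cells (Homo sapiens) for antiproliferative activity, read by MTT assay, with a stated time of 72 h; a lower number here means a stronger inhibitor, a higher number a weaker inhibitor:
Compound 1 `O=C1O[C@H]([C@@H](O)Cn2cc(-c3ccc(Br)cc3)nn2)C(OCc2ccccc2)=C1OCc1ccccc1` gives 750 nM.
Compound 2 `CCCCCCCCCCc1cn(C[C@H](O)[C@H]2OC(=O)C(OCc3ccccc3)=C2OCc2ccccc2)nn1` gives 6750 nM.
Compound 3 `O=C1O[C@H]([C@@H](O)Cn2ccnn2)C(OCc2ccccc2)=C1OCc1ccccc1` gives only a limit of the assay, > 100000 nM.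

Compound 1 holds the lowest of the two numbers, and both compounds that have lost its 4-bromophenyl fall off: a 9.0-fold higher number from compound 1 to compound 2 (0.95 log units; beyond the scatter), and an at least 130-fold higher number from compound 1 to compound 3 (2.12 log units; beyond the scatter). Compound 4 `O=C1O[C@H]([C@@H](O)Cn2cc(CCO)nn2)C(OCc2ccccc2)=C1OCc1ccccc1` makes a related change: 2-hydroxyethyl in place of 4-bromophenyl on an aromatic carbon. Both measured steps point the same way, with compound 3 sitting at the limit (the limit of > 100000 nM in this assay, at which 1 of the 3 values shown sits). For compound 4 a large loss is therefore expected, a 53-fold higher number from compound 1 to compound 4 (1.73 log units; beyond the scatter). Compound 4 is estimated at 40000 nM, between 8000 nM and 100000 nM, with a fair chance that only a limit is reported.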

Compound 4, half-maximal inhibitory concentration: > 100000 nM
Compound 4 gave a limit, no number (the forecaster's own chance of this, stated with the estimate: 35%); middle value at least 2.5-fold (0.39 log units) away from the limit.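

Having a group on this aromatic carbon is not enough on its own: with 2-hydroxyethyl there, the loss from 4-bromophenyl is an at least 130-fold higher number from compound 1 to compound 4 (2.12 log units; beyond the scatter), and the loss from decyl is an at least 14-fold higher number from compound 2 to compound 4 (1.17 log units; beyond the scatter). Compound 4 gives a limit, not a number, and its step with compound 3 cannot be read: the limit of > 100000 nM in this assay, at which 2 of the 4 values shown sit.

Going by these compounds, what stays open is whether the shorter chain or its hydroxy end matters more. A plain ethyl or butyl chain, or phenyl without the bromine, could help separate these possibilities.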